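Extending a Methyl to Ethyl on the Aryl Tetrahydropyridine

The source may report more compounds than this note shows. Statements on the series, on what has been measured and on what is new or still open speak of the compounds shown alone.

Of the compounds shown here, two sharing one core have been measured in an assay on BT-474 cells for inhibition of disintegrin and metalloproteinase domain-containing protein 10 (Homo sapiens); on this read-out higher numbers stand for weaker inhibition and lower numbers for stronger inhibition. Compound 1 `O=C(NO)[C@H]1CC2(CC2)CN[C@@H]1C(=O)N1CCC(c2ccccc2)CC1` carries a phenyl group on a saturated piperidine ring; in this assay compound 1 gives 137 nM. Compound 2 `Cc1cccc(C2=CCN(C(=O)[C@H]3NCC4(CC4)C[C@@H]3C(=O)NO)CC2)c1` instead bears a 3-methylphenyl group on an unsaturated ring; in this assay compound 2 gives 42 nM, the lowest of the two numbers and a step beyond the usual scatter from compound 1.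

Compound 3 `CCc1cccc(C2=CCN(C(=O)[C@H]3NCC4(CC4)C[C@@H]3C(=O)NO)CC2)c1` is the next step from compound 2. The change is methyl in place of hydrogen on a saturated chain carbon bound to an aromatic carbon, so that methyl becomes ethyl. Going by the values given here, no measured pair shows such a change here. A small step, within the scatter, is the expected outcome a 1.2-fold lower number from compound 2 to compound 3 (0.08 log units; within the scatter). Compound 3 is therefore estimated at 35 nM, with a plausible range from 12 nM to 120 nM.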

Compound 3, half-maximal inhibitory concentration: 240 nM
The estimate for compound 3 lay 6.9-fold (0.84 log units) below the measured number, and the stated range ends below it.
By their numbers in this assay, from the lowest: compound 2; then compounds 1 and 3 (each within the scatter of the next).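

Lengthening the 3-methylphenyl group to a 3-ethylphenyl group gives a 5.7-fold higher number from compound 2 to compound 3 (0.76 log units; beyond the scatter) in this assay, which means weaker inhibition. Compound 1 and compound 2 differ in more than one place, so neither could isolate this position; this step shows that one added methyl, on a saturated chain carbon bound to an aromatic carbon, is enough to move the number beyond the scatter. Nothing measured here explains why the number rises.

On these data alone, whether a methoxy group or a longer chain such as propyl in place of the ethyl would bring the number back toward that of compound 2, or raise it further, remains open. Also open, as far as these compounds go, is where a plain phenyl group, with hydrogen in place of the methyl of compound 2, would fall.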